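Swapping chloro for methoxy on a shared core

The source may report more compounds than this note shows. Statements on the series, on what has been measured and on what is new or still open speak of the compounds shown alone.

Compound 1 `Cc1cc(COc2ccccc2Cl)nc(-c2ccccn2)n1` gives 316 nM in a functional assay on cells for antagonist activity at Free fatty acid receptor 1 (Homo sapiens), read by TR-FRET and inositol phosphate accumulation, with a stated time of 2 h; on this read-out higher numbers stand for weaker inhibition and lower numbers for stronger inhibition. Compound 2 `Cc1cc(COc2cccc(Cl)c2)nc(-c2ccccn2)n1` differs from compound 1 by 3-chlorophenyl in place of 2-chlorophenyl on an oxygen on a saturated carbon. In this assay compound 2 gives 398 nM; the step of a 1.3-fold higher number from compound 1 to compound 2 (0.10 log units; within the scatter). Compound 3 `COc1ccccc1OCc1cc(C)nc(-c2ccccn2)n1` carries the change methoxy in place of chloro on an aromatic carbon and gives 2000 nM, so the step of a 6.3-fold higher number from compound 1 to compound 3 (0.80 log units; beyond the scatter). Compound 4 `COc1cccc(OCc2cc(C)nc(-c3ccccn3)n2)c1` has not been measured; it differs from compound 2 by methoxy in place of chloro on an aromatic carbon. This is the same kind of change as from compound 1 to compound 3, though there the new group sits ortho to a large group, whereas here it sits meta to a large group. For the measured compounds named here, from compound 2 to compound 4 a step of about a 5.0-fold higher number from compound 2 to compound 4 (0.70 log units; beyond the scatter) is expected, resting on the single earlier example a 6.3-fold higher number from compound 1 to compound 3 (0.80 log units; beyond the scatter) and on compound 2 giving 398 nM. For compound 4 a value near 2000 nM is expected, plausibly between 800 nM and 5000 nM.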

Compound 4, half-maximal inhibitory concentration: 2000 nM
Estimate against measurement, compound 4: no gap at the digits printed; the measured number falls inside the stated range.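

In this assay, methoxy in place of chloro gives a 5.0-fold higher number from compound 2 to compound 4 (0.70 log units; beyond the scatter). For the compounds shown here, the swap therefore raises the number by a similar amount on both cores, so here the change carries from one core to the other: the same change on two cores in this assay, a 6.3-fold higher number (0.80 log units; beyond the scatter) from compound 1 to compound 3 and a 5.0-fold higher number (0.70 log units; beyond the scatter) from compound 2 to compound 4, 1.3-fold (0.10 log units) apart, within the scatter of two such steps This rests on only two pairs in a single assay, so it sets no rule for other cores and does not explain why methoxy gives the higher number.

The compounds shown leave open whether a fluoro, a trifluoromethyl or a hydroxyl in place of the chloro would behave more like chloro or like methoxy. As far as these compounds go, how an amine or a carboxylic acid on the same ring would read out also remains open.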